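The source may hold more compounds than are shown below. What is called first, only, known or untested is meant among the compounds shown, and "the series" means these compounds.

Compounds measured so far:
Compound 1, `CNc1ncnc2c1c(-c1cccs1)cn2[C@@H]1O[C@H](CO)[C@@H](O)[C@H]1O`, gives > 20000 nM in a functional assay on CEM-DNR-bulk cells (Homo sapiens), read by MTT assay, with a stated time of 72 h; on this read-out lower numbers stand for stronger inhibition and higher numbers for weaker inhibition.
Compound 2, `CSc1ncnc2c1c(-c1cccs1)cn2[C@@H]1O[C@H](CO)[C@@H](O)[C@H]1O`, gives > 20000 nM in this assay.
Compound 3, `CN(C)c1ncnc2c1c(-c1cccs1)cn2[C@@H]1O[C@H](CO)[C@@H](O)[C@H]1O`, gives > 20000 nM in this assay.

Each of these three values is a limit of this assay and not a number, as the limit of > 20000 nM in this assay, at which 3 of the 3 values shown sit, records. Compound 2 therefore stands at the limit, alongside the two other values, which are limits as well. The steps among the three are unreadable for that reason: a step that the two limits leave unreadable from compound 1 to compound 2, a step that the two limits leave unreadable from compound 1 to compound 3 and a step that the two limits leave unreadable from compound 2 to compound 3.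

Compound 4, `C#Cc1cn([C@@H]2O[C@H](CO)[C@@H](O)[C@H]2O)c2ncnc(SC)c12`, keeps the methylsulfanyl group of compound 2 and changes the substituent on the five-membered ring: ethynyl in place of thiophen-2-yl on an aromatic carbon. Among the measured compounds shown here, none of the measured steps touches this position, since compound 1, compound 2 and compound 3 all carry the thiophen-2-yl group, so no measured step bears on the change, and the three limits give no size to anchor on. The expectation for compound 4 in this assay is thus uncertain in both directions, and the estimated step of an at least 6.6-fold lower number from compound 2 to compound 4 (0.82 log units; beyond the scatter) is one that may land below the limit. Compound 4 is expected to give about 3000 nM in this assay, within a range from 100 nM to 20000 nM.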

Compound 4, half-maximal inhibitory concentration: 110 nM
Compound 4: the middle estimate sits 27-fold (1.44 log units) above what was measured, within the range that was stated.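

Among the compounds shown here, this position is the first place where a change can be read: in this assay, ethynyl in place of thiophen-2-yl on an aromatic carbon of the five-membered aromatic ring gives an at least 180-fold lower number from compound 2 to compound 4 (2.25 log units; beyond the scatter), a large step beyond the scatter. The earlier compounds shown here varied only the other substituent, among methylamino, methylsulfanyl and dimethylamino, and the steps among them cannot be read, so they showed nothing about how far the read-out could move on this core. With compound 4, the replacement of an aromatic ring by a group with no ring and a triple bond brings the value off the limit, and the printed size is only the smallest the step can be, since the value for compound 2 is a limit of the assay: the limit of > 20000 nM in this assay, at which 3 of the 4 values shown sit.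

The compounds shown leave open whether the methylamino or dimethylamino group would give a comparable result alongside ethynyl. They also leave open whether the gain follows from losing thiophen-2-yl or from gaining ethynyl, which a plain hydrogen, a longer propynyl chain or a phenyl ring at this position could help separate.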